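A few compounds are considered here, and "the series" means these few. Any claim that something is new, unique, unknown or untested is made for them only; others in the source may bear on it.

Measured so far in an ADME assay on HepG2 2.2.15 cells (Homo sapiens) for cytotoxicity; a lower number here means that less compound is tolerated, a higher number that more compound is tolerated:
compound 1 `CC(=O)N1CCC(C(=O)OCCc2c(-c3ccccc3Cl)c3cc(Cl)ccc3[nH]c2=O)CC1` gives 82000 nM
compound 2 `O=C(OCCc1c(-c2ccccc2Cl)c2cc(Cl)ccc2[nH]c1=O)c1ccc([N+](=O)[O-])cc1` gives 1600000 nM

Among the compounds with values here, compound 2 holds the higher of the two numbers in this assay; the only measured step, a 20-fold higher number from compound 1 to compound 2 (1.29 log units; beyond the scatter), leads to it. Compound 3 `COc1ccccc1/C=C/C(=O)OCCc1c(-c2ccccc2Cl)c2cc(Cl)ccc2[nH]c1=O` is not yet measured. Compared with compound 2 the change is 2-(2-methoxyphenyl)ethenyl in place of 4-nitrophenyl on a carbonyl carbon. Within the data shown here, the one measured step sits on the same carbonyl carbon, but it exchanged 1-acetylpiperidin-4-yl for 4-nitrophenyl, not 4-nitrophenyl for 2-(2-methoxyphenyl)ethenyl; it shows that this position can move the number a great deal, yet not in which direction the present exchange goes. Among the measured compounds shown here, no step bears directly on the change. The step of a 1.8-fold lower number from compound 2 to compound 3 (0.25 log units; within the scatter) is therefore expected to stay within the scatter, with the uncertainty widened on both sides. The estimate for compound 3 in this assay is 900000 nM, with a range of 200000 nM to 3000000 nM.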

Compound 3, half-maximal cytotoxic concentration: 770000 nM
The estimate for compound 3 lay 1.2-fold (0.07 log units) above the measured number, within the range that was stated.
By their numbers in this assay, from the lowest: compound 1; then compound 3; then compound 2.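

In this assay, 2-(2-methoxyphenyl)ethenyl in place of 4-nitrophenyl on the carbonyl carbon gives a 2.1-fold lower number from compound 2 to compound 3 (0.32 log units; beyond the scatter), a modest move that shows this position can also take a second group with an aromatic ring and change the number far less than the earlier exchange did. The same group in place of 1-acetylpiperidin-4-yl gives a 9.4-fold higher number from compound 1 to compound 3 (0.97 log units; beyond the scatter), so both groups with a six-membered aromatic ring stand above compound 1, and none of the three compounds goes against this. No measurement available here accounts for these differences.

As far as these compounds go, whether the number follows the ethenyl link, the methoxy group or the aromatic ring alone remains open. A plain phenyl, a simple amine or a carboxylic acid on the same carbonyl carbon would help separate these readings.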